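Acid ceramidase series: piperidine nitrogen substituent, compound 4

A few compounds are considered here, and "the series" means these few. Any claim that something is new, unique, unknown or untested is made for them only; others in the source may bear on it.

Measured compounds:
compound 1 `CC(C)N1CCN(c2ccc3c(c2)oc(=O)n3C(=O)NCCCCc2ccccc2)CC1` — 211 nM
compound 2 `O=C(NCCCCc1ccccc1)n1c(=O)oc2cc(C3CCOCC3)ccc21` — 68 nM
compound 3 `CC(C)N1CCC(c2ccc3c(c2)oc(=O)n3C(=O)NCCCCc2ccccc2)CC1` — 94 nM

Values are from an assay on HEK293 cells for inhibition of acid ceramidase (Homo sapiens), read by fluorescence, with stated times of 10 min and 3 h; a higher number here means a weaker inhibitor, a lower number a stronger inhibitor. Compound 3 sits second highest of the three: against compound 2 the step of a 1.4-fold higher number from compound 2 to compound 3 (0.14 log units; within the scatter) is within the scatter, while against compound 1 the step of a 2.2-fold lower number from compound 1 to compound 3 (0.35 log units; beyond the scatter) is beyond it. Compound 4 `CC(=O)N1CCC(c2ccc3c(c2)oc(=O)n3C(=O)NCCCCc2ccccc2)CC1` differs from compound 3 by acetyl in place of isopropyl on an amine nitrogen in a ring. Within the data shown here, no measured step alters the substituent on that nitrogen; the nearest comparison is the neutral oxan-4-yl of compound 2 against the 1-isopropylpiperidin-4-yl of compound 3, which gave a step within the scatter. The step of a 1.2-fold lower number from compound 3 to compound 4 (0.07 log units; within the scatter) is therefore expected to stay within the scatter. Compound 4 is estimated at 80 nM in this assay, with a range of 35 nM to 200 nM.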

Compound 4, half-maximal inhibitory concentration: 64 nM
Beside the measured number, compound 4's estimate is 1.3-fold (0.10 log units) above it; the range from low to high includes it.
By their numbers in this assay, from the lowest: compounds 4, 2 and 3 (each within the scatter of the next); then compound 1.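

In this assay, among these compounds, the ring nitrogen takes acetyl in place of isopropyl with no step beyond the scatter (a 1.5-fold lower number from compound 3 to compound 4 (0.17 log units; within the scatter)), the first reading of a change at this atom. The 1-acetylpiperidin-4-yl group also reads level with oxan-4-yl (a 1.1-fold lower number from compound 2 to compound 4 (0.03 log units; within the scatter)), while the gap from the 4-isopropylpiperazin-1-yl group stays beyond the scatter (a 3.3-fold lower number from compound 1 to compound 4 (0.52 log units; beyond the scatter)). Nothing on hand explains these steps.

Open, as far as these compounds go, is whether a free secondary amine, a benzoyl group or a methanesulfonyl group on this nitrogen stays in the same range. Also open, from the compounds shown here alone, is whether acetyl on the piperazine nitrogen would close the gap.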